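The source may hold more compounds than are shown below. What is called first, only, known or untested is meant among the compounds shown, and "the series" means these compounds.

In an ADME assay on WI-38 cells (Homo sapiens) for cytotoxicity, read by MTT assay, with a stated time of 48 h (a higher number here means a weaker inhibitor, a lower number a stronger inhibitor), compound 1 (`CC(C)(Oc1ccc(Cl)cc1)C(=O)NCCOC(=S)Nc1ccc(F)cc1`) gives > 800000 nM as a limit of the assay and not as a number. Compound 2 (`O=C(NCCOC(=S)Nc1ccc(F)cc1)c1cccnc1`) gives > 800000 nM which is likewise a limit. Compound 3 (`Cc1cnc(C(=O)Oc2ccc(C(N)=S)cc2)c[n+]1[O-]`) gives > 800000 nM which is again a limit. Compound 1 therefore has no exact reading and stands with the other two at the limit of > 800000 nM in this assay, at which 3 of the 3 values shown sit, in the record so far.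

Compound 4 (`Cc1ccc(NC(=S)OCCNC(=O)C(C)(C)Oc2ccc(Cl)cc2)cc1`) keeps the rest of compound 1 and changes one substituent, with methyl in place of fluoro on an aromatic carbon, para to a large group. The 4-fluorophenyl thus becomes 4-methylphenyl, and methyl in place of fluoro on an aromatic carbon is the whole difference. For the measured compounds named here, no measured pair shows what this change does in this assay and the expectation rests on compound 1 with its limit of > 800000 nM as the only anchor. The expected outcome is a number no higher from compound 1 to compound 4 (the limit leaves the size open) and so no step beyond the scatter, in no particular direction. Compound 4 is estimated at 800000 nM with an expected range of 400000 nM to 1600000 nM and will probably be reported as a limit too.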

Compound 4, half-maximal inhibitory concentration: > 800000 nM
Compound 4 was reported as a limit; the forecaster's own chance of this, stated with the estimate: 85%; the middle value lies on the limit itself.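

In this assay, for the compounds shown here, compound 1 and compound 4 both stand at a limit and not at a number, so no step between them can be read: the limit of > 800000 nM in this assay, at which 4 of the 4 values shown sit.

The compounds shown leave open what methyl in place of fluoro on an aromatic carbon does in this assay, and where any of them would reach half-maximal inhibition.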